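Anilide series on a shared trimethoxybenzophenone-bearing core: notes

The source may report more compounds than this note shows. Statements on the series, on what has been measured and on what is new or still open speak of the compounds shown alone.

Measured so far:
compound 1, `COc1ccc(C(=O)c2cc(OC)c(OC)c(OC)c2)cc1NC(=O)/C=C/c1cc(OC)c(OC)c(OC)c1`; in a functional assay on DU-145 cells (Homo sapiens) for cytotoxicity, read by MTT assay, with a stated time of 72 h (a lower number here means a stronger inhibitor, a higher number a weaker inhibitor), compound 1 gives 6300 nM
compound 2, `COc1ccc(C(=O)c2cc(OC)c(OC)c(OC)c2)cc1NC(=O)/C=C/c1ccc(C(F)(F)F)cc1`; in this assay compound 2 gives 4300 nM
compound 3, `COc1cc(/C=C/C(=O)Nc2cc(C(=O)c3cc(OC)c(OC)c(OC)c3)ccc2OC)ccc1F`; in this assay compound 3 gives 12100 nM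

Compound 1 sits second highest of the three numbers; its nearest neighbour is compound 2 and the furthest is compound 3, and neither gap is beyond the scatter. The two steps away from compound 1 are a 1.5-fold lower number from compound 1 to compound 2 (0.17 log units; within the scatter) and a 1.9-fold higher number from compound 1 to compound 3 (0.28 log units; within the scatter), both within the scatter; only a 2.8-fold higher number from compound 2 to compound 3 (0.45 log units; beyond the scatter), which does not touch compound 1, counts as a modest change.

Compound 4, `COc1ccc(C(=O)c2cc(OC)c(OC)c(OC)c2)cc1NC(=O)/C=C/c1ccc(N)cc1`, differs from compound 1 in one place: 4-aminophenyl in place of 3,4,5-trimethoxyphenyl on a double-bonded chain carbon bound to a double-bonded chain carbon. Among the measured compounds shown here, both steps that bear on this position left the number essentially unchanged, and no compound carrying an amino group has been measured, so the step from compound 1 to compound 4 is expected to stay within the scatter, with no direction asserted. The expected step is a 1.1-fold lower number from compound 1 to compound 4 (0.02 log units; within the scatter). Compound 4 is therefore estimated at 6000 nM, in a range from 2500 nM to 15000 nM.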

Compound 4, half-maximal inhibitory concentration: 13500 nM
Estimate against measurement, compound 4: 2.3-fold (0.35 log units) below, and the stated range covers the measured number.
By their numbers in this assay, from the lowest: compounds 2, 1, 3 and 4 (each within the scatter of the next, the first and the last beyond it).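

At this position a change away from 3,4,5-trimethoxyphenyl now gives a step beyond the scatter in this assay: a 2.1-fold higher number from compound 1 to compound 4 (0.33 log units; beyond the scatter), the first from compound 1 to pass it. The direct exchange of amino for trifluoromethyl on an aromatic carbon gives a 3.1-fold higher number from compound 2 to compound 4 (0.50 log units; beyond the scatter), so the substituent on this ring can separate two otherwise identical compounds, whereas a 1.1-fold higher number from compound 3 to compound 4 (0.05 log units; within the scatter) leaves 4-aminophenyl and 4-fluoro-3-methoxyphenyl unresolved. No independent evidence bears on the origin of these steps.

From the compounds shown here alone, whether hydroxyl or dimethylamino in place of amino on an aromatic carbon would stay close to compound 4 or approach compound 2 remains open. Also open, going by these compounds, is what a saturated chain in place of the double-bonded chain would do to these differences.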